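This account rests on a few compounds, and the source may have more. Where it says the series, first, only, none or still open, it means among the compounds named here.

Measured compounds in an assay on CHO cells for displacement of a labelled ligand from adenosine receptor A3 (Homo sapiens), read by scintillation counting, with a stated time of 45 min, in the presence of a further agent that is not named here; on this read-out higher numbers stand for weaker inhibition and lower numbers for stronger inhibition:
- compound 1 `CCCn1c(=O)[nH]c2nc(-c3ccc(S(=O)(=O)N4CCN(c5cccc(F)c5)CC4)cc3)[nH]c2c1=O` gives > 1000 nM, which is a limit of the assay, not a number.
- compound 2 `CCCn1c(=O)[nH]c2nc(-c3ccc(S(=O)(=O)N4CCN(Cc5cccc(C)c5)CC4)cc3)[nH]c2c1=O` gives > 1000 nM, again only a limit.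
- compound 3 `CCCn1c(=O)[nH]c2nc(-c3ccc(S(=O)(=O)N4CCN(Cc5ccc(Br)c(F)c5)CC4)cc3)[nH]c2c1=O` gives > 1000 nM, likewise a limit.

Compound 3 therefore stands at the limit of > 1000 nM in this assay, at which 3 of the 3 values shown sit; no value in this assay separates it from the other two. The steps between the measured compounds, a step that the two limits leave unreadable from compound 1 to compound 2, a step that the two limits leave unreadable from compound 1 to compound 3 and a step that the two limits leave unreadable from compound 2 to compound 3, are all unreadable in size and direction, since each runs from one limit to another.

The next compound, compound 4 `CCCn1c(=O)[nH]c2nc(-c3ccc(S(=O)(=O)N4CCN(c5ccc(C)cc5)CC4)cc3)[nH]c2c1=O`, differs from compound 3 by 4-methylphenyl in place of 4-bromo-3-fluorobenzyl on an amine nitrogen in a ring. Compound 1 is the nearest comparison: there the group on the ring nitrogen is also an aryl bound directly to that nitrogen rather than a benzyl, and compound 1 sits at the same limit as compounds 2 and 3. None of the measured steps gives a readable size, so no direction beyond the scatter can be drawn from them; the only evidence is that all three shown variations at this nitrogen stay at the limit of > 1000 nM in this assay, at which 3 of the 3 values shown sit.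

On that basis compound 4 is expected to remain at the limit as well, with an estimated value of 3000 nM, range 800 nM to 20000 nM. The step this estimate implies, a step that the limit leaves unreadable from compound 3 to compound 4, is expected to be no change that the assay can read.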

Compound 4, inhibition constant: > 1000 nM
Compound 4 gave a limit, no number; the forecaster's own chance of this, stated with the estimate: 75%; the middle value does not contradict the limit.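

The steps to compound 4 from compound 1, compound 2 and compound 3 run from limit to limit in this assay, so none of them can be read in size or direction. Whether any group on the amine nitrogen in the ring would give a number in this assay stays open, with the compounds shown all at one place: the limit of > 1000 nM in this assay, at which 4 of the 4 values shown sit.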